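Fluoro for methylsulfanyl on a shared core

This account rests on a few compounds, and the source may have more. Where it says the series, first, only, none or still open, it means among the compounds named here.

Measured so far:
compound 1 `CS(=O)(=O)c1nc(N)c2nnn(C3O[C@H](CO)[C@@H](O)[C@H]3O)c2n1`: 14000 nM
compound 2 `CSc1nc(N)c2nn(C3O[C@H](CO)[C@@H](O)[C@H]3O)nc2n1`: 25000 nM

In a functional assay on HEp-2 cells (Homo sapiens) for cytotoxicity (on this read-out higher numbers stand for weaker inhibition and lower numbers for stronger inhibition), compound 2 at 25000 nM lies within the usual scatter of compound 1 at 14000 nM and the two cannot be told apart. Neither value shows strong inhibition on these cells.

The next compound is compound 3 `Nc1nc(F)nc2nn(C3O[C@H](CO)[C@@H](O)[C@H]3O)nc12` which keeps the core of compound 2 and changes one group: fluoro in place of methylsulfanyl on an aromatic carbon. In plain terms, this is fluoro in place of methylsulfanyl on an aromatic carbon, between two ring nitrogen atoms.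

Among the measured compounds shown here, no two measured compounds differ in just one place, so no earlier step shows what a swap of this kind does. The expectation is therefore a judgment call with wide margins. A moderate move toward stronger inhibition in this assay is expected, although a result within the scatter of compound 2 would not be surprising. The estimated change is a 3.1-fold lower number from compound 2 to compound 3 (0.49 log units; beyond the scatter) and it carries real uncertainty. For compound 3 the estimated value is 8000 nM with an expected range from 1000 nM to 40000 nM in this assay.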

Compound 3, half-maximal inhibitory concentration: > 75000 nM
Compound 3 ended at the assay's limit (the forecaster's own chance of this, stated with the estimate: 15%); middle value at least 9.3-fold (0.97 log units) away from the limit.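

In this assay, compound 3 gives > 75000 nM, which is a limit of the assay and not a number. Placing fluoro instead of methylsulfanyl on this aromatic carbon, between two ring nitrogen atoms, is the first single change that can be read in this series, and it gives an at least 3.0-fold higher number from compound 2 to compound 3 (0.47 log units; beyond the scatter). This shows that the group at this position affects the read-out and that this swap moves it toward weaker inhibition, although the size of the step is only a lower bound, with compound 3 being the one compound shown that sits at the edge of the measurable range: the limit of > 75000 nM in this assay, at which 1 of the 3 values shown sits.

This single step cannot separate the effect of removing methylsulfanyl from the effect of adding fluoro, so it does not show which group drives the difference or why. From the compounds shown here alone, what an amine, a methoxy group or a longer chain such as ethylsulfanyl would do on this same carbon remains open, as does whether the swap would have a similar result on a different core.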